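The source may report more compounds than this note shows. Statements on the series, on what has been measured and on what is new or still open speak of the compounds shown alone.

Of the compounds shown here, three built on one shared core have been tested in a functional assay on MDA-MB-231 cells (Homo sapiens) for antiproliferative activity, read by MTT assay, with a stated time of 24 h; a lower number here means a stronger inhibitor, a higher number a weaker inhibitor. Compound 1 `c1ccc(-c2noc(-c3ccncc3)n2)cc1` gives > 1000000 nM, which is a limit of the assay rather than a number. Compound 2 `COc1ccc(-c2noc(-c3ccc(F)cc3)n2)cc1O` likewise gives > 1000000 nM, again a limit and not a measured number. For the measured compounds named here, compound 3 `COc1ccc(-c2noc(-c3ccc(Cl)cc3)n2)cc1OC1CCCC1` is the only one of the three to return an actual number, at 396000 nM, so it stands as the single measured value in the set. The remaining two values are described by the limit of > 1000000 nM in this assay, at which 2 of the 3 values shown sit. Going by the values given here, no two of these measured compounds differ in just one place, so no step between them can be stated.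

The next compound, compound 4 `COc1ccc(-c2noc(C3CCCN3)n2)cc1OC1CCCC1`, has not yet been measured in this assay. It departs from compound 3 by pyrrolidin-2-yl in place of 4-chlorophenyl on an aromatic carbon. The change sits on an aromatic carbon of the five-membered aromatic ring with two nitrogen and one oxygen, next to the ring nitrogen and next to the ring oxygen. Among the compounds with values here, with no measured step of this kind to lean on, the expectation rests on compound 3 alone, and a step toward weaker inhibition, a 2.0-fold higher number from compound 3 to compound 4 (0.31 log units; beyond the scatter), is expected. Compound 4 is estimated to give 800000 nM in this assay, with a range from 200000 nM to 3000000 nM, and a real chance that only a limit is reported.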

Compound 4, half-maximal inhibitory concentration: 212000 nM
For compound 4 the middle estimate is 3.8-fold (0.58 log units) above the measured one; low and high end bracket the measured number.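

For the compounds shown here, the first measured step at this position, an aromatic carbon of the five-membered aromatic ring with 2 nitrogen and 1 oxygen, comes in this assay as a 1.9-fold lower number from compound 3 to compound 4 (0.27 log units; within the scatter). Here 4-chlorophenyl, with its six-membered aromatic ring of carbon only, gives way to pyrrolidin-2-yl, a five-membered non-aromatic ring with 1 hydrogen-bond donor and 1 hydrogen-bond acceptor, yet the two compounds cannot be told apart in this test, so for this pair an aromatic ring at this place is not needed to keep the number at this level. Compound 3 and compound 4 are also the only two in the set with actual numbers, and the rest is a limit: the limit of > 1000000 nM in this assay, at which 2 of the 4 values shown sit.

Going by these compounds, it remains open whether any group at this position can move the number beyond the scatter, for example a carboxylic acid, an open-chain amine or a piperidine ring. A plain cyclopentyl ring at the same place would show whether the ring nitrogen of pyrrolidin-2-yl counts on its own.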